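The source may hold more compounds than are shown below. What is called first, only, known or untested is meant among the compounds shown, and "the series" means these compounds.

In a functional assay on MCF7 cells (Homo sapiens) for cytotoxicity, read by MTT assay, with a stated time of 72 h, tested at 30 uM (a higher number here means more inhibition of growth at the concentration tested, a lower number less inhibition of growth), two compounds have been measured. Compound 1 `N/C(=N\NC(=S)N1CCCC1)c1ccc(F)cn1` gives 60.6%. Compound 2 `N/C(=N\NC(=S)N1CCCCC1)c1ccccn1` gives 69.3%, the higher of the two numbers, though the gap to compound 1 stays within the usual scatter, so the two cannot be told apart on these figures. Compound 3 `N/C(=N\NC(=S)N1CCCC1)c1ccccn1` has not yet been measured. It differs from compound 2 by pyrrolidin-1-yl in place of piperidin-1-yl on a thiocarbonyl carbon. Going by the values given here, no pair of measured compounds differs in this one place alone, since compound 1 carries the smaller ring together with a fluorine on the shared core while compound 2 carries the larger ring without it, so the effect of the ring size on its own has not been isolated. With the two measured values so close to each other, the step from compound 2 to compound 3 is expected to be small, a number 6.3 percentage points lower from compound 2 to compound 3 (within the scatter), and not beyond the scatter in either direction. Compound 3 is therefore estimated to give 63% in this assay, with a range from 45% to 78%.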

Compound 3, percent growth inhibition at one concentration: 54.6%
Beside the measured number, compound 3's estimate is 8.4 percentage points above it, within the range that was stated.
By their numbers in this assay, from the lowest: compounds 3, 1 and 2 (each within the scatter of the next, the first and the last beyond it).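

Pyrrolidin-1-yl in place of piperidin-1-yl on a thiocarbonyl carbon gives a number 14.7 percentage points lower from compound 2 to compound 3 (beyond the scatter) in this assay and thus isolates the ring on this carbon for the first time, since compound 1 and compound 2 differ in two places and could not separate the five-membered ring from the six-membered one. Hydrogen in place of fluoro on an aromatic carbon gives a number 6 percentage points lower from compound 1 to compound 3 (within the scatter) and so leaves no readable difference between these two compounds at this concentration, which means that the ring change is the only one of the two single changes that stands out from the scatter. Nothing available here accounts for the step at the thiocarbonyl carbon.

The compounds shown span only two ring sizes on the thiocarbonyl carbon, so it remains open whether a seven-membered azepan-1-yl ring, a morpholin-4-yl ring or an open-chain dimethylamino group would give a number like that of the piperidin-1-yl compound or like that of the pyrrolidin-1-yl compound. On these data alone, the fluoro change has also been read only with pyrrolidin-1-yl on that carbon, and whether it would behave the same way with piperidin-1-yl remains open.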